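The compounds below may be only part of what the source reports. "The series", "measured", "known", "first", "only" and "open" are said of these compounds alone.

Measured so far, in a functional assay on HEK293 cells for agonist activity at D(4) dopamine receptor (Homo sapiens), read by FLIPR; a higher number here means a larger maximal response, a lower number a smaller maximal response:
- compound 1 `COc1ccccc1C1CCN(CC(=O)Nc2cccc(C)c2)CC1`: 43%
- compound 2 `Cc1cccc(NC(=O)CN2CCC(c3ccc(O)cn3)CC2)c1`: 83%

Compound 2 stands highest of the two, with compound 1 the nearest, the step being a number 40 percentage points higher from compound 1 to compound 2 (beyond the scatter). Compound 3 `Cc1cccc(NC(=O)CN2CCC(c3ccccc3C#N)CC2)c1` differs from compound 2 by 2-cyanophenyl in place of 5-hydroxypyridin-2-yl on a saturated ring carbon. For the measured compounds named here, the only step that bears on it is a number 40 percentage points higher from compound 1 to compound 2 (beyond the scatter), which runs the other way: it goes from a six-membered aromatic ring of carbon only to the 5-hydroxypyridin-2-yl, and here that ring leaves again. So a downward step in this assay is expected, of the size a number 33 percentage points lower from compound 2 to compound 3 (beyond the scatter). Compound 3 is therefore estimated at 50%, between 30% and 75%.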

Compound 3, largest response reached (reported as efficacy), in percent of the reference or control that the assay uses: 71%
The estimate for compound 3 lay 21 percentage points below the measured number; measured number inside the range.
By their numbers in this assay, from the lowest: compound 1; then compound 3; then compound 2.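

The step of a number 12 percentage points lower from compound 2 to compound 3 (beyond the scatter) is modest in this assay, so a large response at this position does not depend on 5-hydroxypyridin-2-yl and its hydrogen-bond donor: 2-cyanophenyl, with a ring of carbon only, retains much of it. The step of a number 28 percentage points higher from compound 1 to compound 3 (beyond the scatter) shows that, with the phenyl ring kept, cyano in place of methoxy on an aromatic carbon is enough to shift the response. No measurement at hand explains either step. The compounds shown leave open how an amine or a carboxylic acid would fare on that aromatic carbon, and how an unsubstituted phenyl ring would compare.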